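This account rests on a few compounds, and the source may have more. Where it says the series, first, only, none or still open, it means among the compounds named here.

Of the compounds shown here, three sharing one urea-linked core have been tested in a functional assay on NCI-H520 cells (Homo sapiens) for inhibition, read by MTT assay, with a stated time of 48 h, tested at 10 uM; a lower number here means less inhibition, a higher number more inhibition at the concentration tested (going by the name of the read-out). Compound 3 `COc1cc(NC(=O)Nc2cc(Nc3cc(I)ccc3OC)ncn2)cc(OC)c1` gives 55%, the highest of the three values. Compound 1 `COc1cc(NC(=O)Nc2cc(Nc3cc(C)cc(F)c3)ncn2)cc(OC)c1` gives 24.5%, and compound 2 `CC(C)(C)c1ccc(Nc2cc(NC(=O)Nc3c(Cl)cccc3Cl)ncn2)cc1` gives 22%. For the measured compounds named here, the single measured step at the aryl group on the nitrogen on the aromatic ring, a number 30.5 percentage points higher from compound 1 to compound 3 (beyond the scatter), shows how strongly that group can move this assay. Compound 4 `COc1cc(NC(=O)Nc2cc(Nc3ccc(C(C)(C)C)cc3)ncn2)cc(OC)c1` is not yet measured; it differs from compound 3 by 4-(tert-butyl)phenyl in place of 5-iodo-2-methoxyphenyl on a nitrogen on an aromatic ring. Compound 2 already carries 4-(tert-butyl)phenyl on that nitrogen, though with a different urea end, and its value lies well below that of compound 3. Compound 4 is therefore expected to drop, with an estimated step of a number 27 percentage points lower from compound 3 to compound 4 (beyond the scatter). The estimate for compound 4 is 28%, ranging from 12% to 48%.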

Compound 4, a percentage reported as inhibition, at one concentration (the size of the read-out at that concentration, not a potency): 17.5%
Compound 4: the middle estimate sits 10.5 percentage points above what was measured; measured number inside the range.
By their numbers in this assay, from the lowest: compounds 4, 2 and 1 (each within the scatter of the next); then compound 3.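

In this assay, the aryl group on the nitrogen gives a second large step (a number 37.5 percentage points lower from compound 3 to compound 4 (beyond the scatter)), while swapping 4-(tert-butyl)phenyl for 3-fluoro-5-methylphenyl there changes little (a number 7 percentage points lower from compound 1 to compound 4 (within the scatter)), so 5-iodo-2-methoxyphenyl stands apart from both. With 4-(tert-butyl)phenyl in that place, changing the urea end also changes little (a number 4.5 percentage points lower from compound 2 to compound 4 (within the scatter)). Nothing measured here explains the difference. From the compounds shown here alone, whether the iodine or the methoxy group matters more remains open, as does the effect of an amine or a carboxylic acid on that aromatic ring.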